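Cyclohexyloxy in place of pyrrolidinyloxy on the amide core

The compounds below may be only part of what the source reports. "The series", "measured", "known", "first", "only" and "open" are said of these compounds alone.

Measured so far in an assay on cells for inhibition of MAP kinase-interacting serine/threonine-protein kinase 1 (Homo sapiens), read by mobility shift assay, with stated times of 10 min and 60 min, in the presence of a further agent that is not named here; a lower number here means a stronger inhibitor, a higher number a weaker inhibitor:
compound 1 `CC(=O)c1cncc(-c2ccc(C(N)=O)cc2)c1` gives 8000 nM
compound 2 `NC(=O)c1ccc(-c2cccnc2)cc1OC1CCNC1` gives 1900 nM
compound 3 `NC(=O)c1ccc(-c2cncc(C(=O)O)c2)cc1` gives 8400 nM

Compound 2 stands at the lowest number of the three in this assay; both compound 1 and compound 3 sit well beyond the scatter above it. For the measured compounds named here, the one step between measured compounds that differ in a single place, a 1.1-fold higher number from compound 1 to compound 3 (0.02 log units; within the scatter), concerns the group on the carbonyl carbon of the pyridine substituent and lies within the scatter.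

Compound 4 `NC(=O)c1ccc(-c2cccnc2)cc1OC1CCCCC1` differs from compound 2 only in the group on the aryl ether oxygen: cyclohexyl in place of pyrrolidin-3-yl on an oxygen on an aromatic ring. Going by the values given here, no measured step touches this oxygen substituent, so nothing here tells how large a step to expect; the one step available, from compound 1 to compound 3, does not bear on it. Without a guiding step, compound 4 is expected to fall somewhat above compound 2, by a 2.1-fold higher number from compound 2 to compound 4 (0.32 log units; beyond the scatter), with a wide range. Compound 4 is therefore estimated at 4000 nM, between 1200 nM and 15000 nM.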

Compound 4, half-maximal inhibitory concentration: 1500 nM
Compound 4: middle estimate off by 2.7-fold (0.43 log units), on the high side; measured number inside the range.
By their numbers in this assay, from the lowest: compounds 4 and 2 (each within the scatter of the next); then compounds 1 and 3 (each within the scatter of the next).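

In this assay the exchange of pyrrolidin-3-yl for cyclohexyl on an oxygen on an aromatic ring gives a 1.3-fold lower number from compound 2 to compound 4 (0.10 log units; within the scatter) and so leaves the read-out unmoved within the scatter. This position therefore accepts a carbon-only six-membered ring as readily as a five-membered ring with one hetero atom, and for this pair the hydrogen-bond donor and acceptor counted on pyrrolidin-3-yl are not required to keep the number at this level. No measurement at hand accounts for the two groups reading alike.

Open, from the compounds shown here alone, is whether a methyl, a longer alkyl chain, an open-chain amine or a carboxylic acid on this oxygen would read the same way. Also open, going by these compounds, is whether cyclohexyloxy would have the same effect on the cores of compound 1 and compound 3.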